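From a methyl amide to a dimethylmorpholine amide

The compounds below may be only part of what the source reports. "The series", "measured", "known", "first", "only" and "open" are said of these compounds alone.

Compound 1 `O=C(CCc1ccc(NC(=O)Nc2ccc(Cl)c(C(F)(F)F)c2)cc1)NC1CCC1`: > 50000 nM
Compound 2 `CNC(=O)CCc1ccc(NC(=O)Nc2ccc(Cl)c(C(F)(F)F)c2)cc1`: 25200 nM

Both compounds were tested in a functional assay on A-375 cells (Homo sapiens) for inhibition, read by MTT assay, with a stated time of 120 h; on this read-out higher numbers stand for weaker inhibition and lower numbers for stronger inhibition. Compound 1 gives > 50000 nM, which is a limit of the assay and not a number. For the measured compounds named here, compound 2, at 25200 nM, therefore holds the only actual number in the set. Compound 3 `CC1CN(C(=O)CCc2ccc(NC(=O)Nc3ccc(Cl)c(C(F)(F)F)c3)cc2)CC(C)O1` has not yet been measured. It carries 2,6-dimethylmorpholin-4-yl in place of methylamino on a carbonyl carbon. Going by the values given here, only one measured step involves this amide nitrogen: an at least 1.9-fold lower number from compound 1 to compound 2 (0.29 log units; that floor lies within the scatter). That step starts from a limit, so it is a weak guide, and no clear change beyond the scatter is expected, with a slight lean toward weaker inhibition. The expected change is a 1.3-fold higher number from compound 2 to compound 3 (0.10 log units; within the scatter). For compound 3 the estimated value is 32000 nM, with an expected range of 12000 nM to 50000 nM.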

Compound 3, half-maximal inhibitory concentration: > 50000 nM
Compound 3: only a limit was reported; the forecaster's own chance of this, stated with the estimate: 40%; middle value at least 1.5-fold (0.19 log units) away from the limit.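

In this assay compound 3 gives > 50000 nM, which is a limit of the assay and not a number. For the compounds shown here, compound 3 is the first compound here to lack the amide hydrogen, and placing 2,6-dimethylmorpholin-4-yl on the carbonyl carbon in place of methylamino gives an at least 1.9-fold higher number from compound 2 to compound 3 (0.29 log units; that floor lies within the scatter), so no change beyond the scatter is established. The step between compound 1 and compound 3 cannot be read, and this position offers little to compare: the limit of > 50000 nM in this assay, at which 2 of the 3 values shown sit.

The compounds shown do not separate the loss of the amide hydrogen from the larger ring, a question that dimethylamino or unsubstituted morpholine on the same carbonyl carbon would address. From the compounds shown here alone, it also remains open whether a carboxylic acid in place of the amide, or a longer chain, would give a lower number than compound 2.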